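A second methoxy, starting from a limit

The compounds below may be only part of what the source reports. "The series", "measured", "known", "first", "only" and "open" are said of these compounds alone.

Compound 1 `O=C(Nc1nc2ccccc2s1)c1cn(-c2ccccc2)nc1-c1ccccc1` gives 13500 nM
Compound 2 `COc1ccc2nc(NC(=O)c3cn(-c4ccccc4)nc3-c3ccccc3)sc2c1` gives > 50000 nM (a limit)

In a functional assay on A549 cells (Homo sapiens) for cytotoxicity, read by MTT assay, with a stated time of 72 h (a higher number here means a weaker inhibitor, a lower number a stronger inhibitor), compound 2 stands at > 50000 nM as a limit of the assay and not as a number. Compound 3 `COc1ccc(-c2nn(-c3ccccc3)cc2C(=O)Nc2nc3ccc(OC)cc3s2)cc1` differs from it by methoxy in place of hydrogen on an aromatic carbon and so turns phenyl to 4-methoxyphenyl. Going by the values given here, the one measured step bearing on this is the same exchange elsewhere on the molecule, an at least 3.7-fold higher number from compound 1 to compound 2 (0.56 log units; beyond the scatter) and it points towards a higher number. A further modest rise is therefore expected, though from a limit its size stays uncertain. The estimated step runs a step that the limit leaves unreadable from compound 2 to compound 3 in this reading. For compound 3 the expected value is 60000 nM with an estimated range of 20000 nM to 150000 nM in this assay.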

Compound 3, half-maximal inhibitory concentration: 18900 nM
For compound 3 the middle estimate is 3.2-fold (0.50 log units) above the measured one; measured number below the stated range.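

In this assay, turning phenyl to 4-methoxyphenyl gives an at least 2.6-fold lower number from compound 2 to compound 3 (0.42 log units; beyond the scatter), the opposite direction to the same exchange elsewhere on the molecule, an at least 3.7-fold higher number from compound 1 to compound 2 (0.56 log units; beyond the scatter). Across these compounds, then, methoxy in place of hydrogen has no single direction; the outcome differs with its place. Compound 2 at > 50000 nM is a limit of the assay and not a number, so the full size of the new step stays unknown: the limit of > 50000 nM in this assay, at which 1 of the 3 values shown sits.

On these data alone, it remains open whether an amine or a hydroxyl at this place would move the number the same way. Also open, as far as these compounds go, is whether 4-methoxyphenyl would lower the number on the core of compound 1, without the first methoxy.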